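A few compounds are considered here, and "the series" means these few. Any claim that something is new, unique, unknown or untested is made for them only; others in the source may bear on it.

Measured so far in an ADME assay on Vero cells (Chlorocebus sabaeus) for cytotoxicity, read by crystal violet staining; a higher number here means that more compound is tolerated, a lower number that less compound is tolerated:
- compound 1, `c1ccc(/N=N/c2ccc(NC[C@@H]3CCCN4CCCC[C@H]34)c3c2CCCC3)cc1`, 80000 nM
- compound 2, `Cc1ccc(/N=N/N(CCCN(C)C)c2ccccc2)cc1`, 100000 nM
- compound 3, `Cc1ccc(/N=N/c2ccc(NCCCN(C)C)cc2)cc1`, 50000 nM

In this assay compound 1 gives 80000 nM, and this number sits with those of compound 2 and compound 3 inside a single band: its gap to compound 2 and its gap to compound 3 both fall within the usual scatter of repeated measurements, so no order among the three can be claimed. Within the data shown here, no step between two measured compounds that differ in one place has been run, so nothing measured tells how a change on the aryl azo portion moves the read-out.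

Compound 4, `Fc1ccc(/N=N/c2ccc(NC[C@@H]3CCCN4CCCC[C@H]34)c3c2CCCC3)c(F)c1`, differs from compound 1 by 2,4-difluorophenyl in place of phenyl on a double-bonded nitrogen. Among the measured compounds shown here, with no measured step to lean on, the expectation for compound 4 in this assay is a step from compound 1 of the size a 1.1-fold lower number from compound 1 to compound 4 (0.06 log units; within the scatter), that is, none beyond the scatter in either direction. The estimate for compound 4 in this assay is 70000 nM, with a range from 35000 nM to 140000 nM.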

Compound 4, half-maximal cytotoxic concentration: 15000 nM
Compound 4: middle estimate off by 4.7-fold (0.67 log units), on the high side, and the stated range ends above it.
By their numbers in this assay, from the lowest: compound 4; then compounds 3, 1 and 2 (each within the scatter of the next).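

In this assay, among these compounds, the aryl group on the double-bonded nitrogen is not a silent position: 2,4-difluorophenyl in place of phenyl gives a 5.3-fold lower number from compound 1 to compound 4 (0.73 log units; beyond the scatter) as the first step that can be read beyond the scatter. The step arises with the core of compound 1 unchanged, so the outer ring alone is enough to move this read-out, and in the direction of less compound tolerated. Nothing at hand accounts for the size of this step.

Still open, on these data alone, is whether both fluorines are needed, or whether a single fluorine, a chlorine or a methoxy group on this ring would give a similar step. Also open, as far as these compounds go, is whether the same replacement would move the number on the core of compound 3.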